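Pyrrolidine Amide Replacing the Methylamide of Compound 2

The source may hold more compounds than are shown below. What is called first, only, known or untested is meant among the compounds shown, and "the series" means these compounds.

Measured compounds:
- compound 1, `COc1cc(C(N)=O)nn1-c1ccccc1`, 34.3%
- compound 2, `CNC(=O)c1cc(OC)n(-c2ccccc2)n1`, 57.9%
- compound 3, `COc1cc(C(=O)NC(C)C)nn1-c1ccccc1`, 24.8%

In a functional assay on the whole organism (strain Wistar) for inhibition, with Rattus norvegicus as the target, read by paw edema, with stated times of 30 min and 3 h, at a dose of 100 mg/kg by the oral route (on this read-out lower numbers stand for less inhibition and higher numbers for more inhibition at the one dose given (going by the name of the read-out)), compound 2 holds the highest of the three numbers. Its step from compound 1 is a number 23.6 percentage points higher from compound 1 to compound 2 (beyond the scatter), and its step to compound 3 is a number 33.1 percentage points lower from compound 2 to compound 3 (beyond the scatter). Compound 1 and compound 3 differ by a number 9.5 percentage points lower from compound 1 to compound 3 (within the scatter).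

Compound 4, `COc1cc(C(=O)N2CCCC2)nn1-c1ccccc1`, has not yet been measured. It differs from compound 2 in one place: pyrrolidin-1-yl in place of methylamino on a carbonyl carbon.

Among the measured compounds shown here, the steps that bear on this are those that change the amide-type nitrogen. Adding methyl raised the number beyond the scatter, while enlarging methyl to isopropyl lowered it by a large amount. Pyrrolidin-1-yl is the bulkiest group in the series and also removes the hydrogen-bond donor, so compound 4 is expected to fall below compound 2, with a step of a number 27.9 percentage points lower from compound 2 to compound 4 (beyond the scatter). The estimate for compound 4 is 30%, with a range from 10% to 50%.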

Compound 4, a percentage reported as inhibition, in the whole organism at one dose (the size of the read-out at that dose, not a potency): 29.2%
Compound 4: middle estimate off by 0.8 percentage points, on the high side; the measured number falls inside the stated range.
By their numbers in this assay, from the lowest: compounds 3, 4 and 1 (each within the scatter of the next); then compound 2.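

In this assay, the step of a number 28.7 percentage points lower from compound 2 to compound 4 (beyond the scatter) shows that the number of compound 2 is not kept when methylamino gives way to pyrrolidin-1-yl, a five-membered ring whose nitrogen carries no hydrogen-bond donor. The steps of a number 4.4 percentage points higher from compound 3 to compound 4 (within the scatter) and a number 5.1 percentage points lower from compound 1 to compound 4 (within the scatter) both stay within the scatter, so compound 4 joins compound 1 and compound 3 as a group that cannot be told apart. Of the four groups on this carbonyl carbon, only the methylamino of compound 2 stands clear of the others, and no measurement at hand explains why.

On these data alone, whether dimethylamino, which also lacks the amide hydrogen but has no ring, would fall with compound 4 remains open. So does the place of ethylamino, a size step between methylamino and isopropylamino.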